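Swapping the ring-nitrogen cap on a three-compound series

The source may hold more compounds than are shown below. What is called first, only, known or untested is meant among the compounds shown, and "the series" means these compounds.

Within the data shown here, the three compounds measured so far share one core. Compound 1 `CC(C)OC(=O)N1CCC(Oc2ncnc3c2CCN3c2ccc(S(C)(=O)=O)cc2)CC1` gives 154% in a functional assay on CHO-K1 cells with Glucose-dependent insulinotropic receptor (Homo sapiens) as the target, read by a luciferase reporter, with a stated time of 5 h (on this read-out lower numbers stand for smaller maximal responses and higher numbers for larger maximal responses), the highest of the three numbers. Compound 2 `CC(C)OC(=O)N1CCC(Oc2ncnc3c2CCN3c2ccc(-c3nccs3)cc2F)CC1` gives 74% in this assay, the lowest. Among the measured compounds shown here, compound 3 `CCCOC(=O)N1CCC(Oc2ncnc3c2CCN3c2ccc(S(C)(=O)=O)cc2F)CC1` gives 111% in this assay and so stands second highest of the three, a number beyond the scatter below compound 1 and beyond the scatter above compound 2; no single-point steps link these three, so only the bare values can be compared.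

Compound 4 `CS(=O)(=O)c1ccc(N2CCc3c(OC4CCN(C(=S)Sc5ccccc5)CC4)ncnc32)c(F)c1` has not been measured. It differs from compound 3 in one place a group of 9 heavy atoms (7 carbon, 2 sulfur; one six-membered aromatic ring of carbon only) in place of a group of 6 heavy atoms (4 carbon, 2 oxygen; no ring), on an amine nitrogen in a ring: the propoxycarbonyl leaves and a group with no common name enters on the amine nitrogen in the ring. For the measured compounds named here, no measured pair shows what replacing this cap does, so the direction of any step in this assay is open. With the cap changed more strongly than anywhere among compounds 1 to 3, a small downward step is expected for compound 4, giving an estimated 95% with a wide range from 50% to 140%, meaning an expected step of a number 16 percentage points lower from compound 3 to compound 4 (beyond the scatter).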

Compound 4, largest response reached (reported as percent of maximum), in percent of the reference or control that the assay uses: 103%
Compound 4: the middle estimate sits 8 percentage points below what was measured; the measured number falls inside the stated range.
By their numbers in this assay, from the lowest: compound 2; then compounds 4 and 3 (each within the scatter of the next); then compound 1.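

Among these compounds, this is the first pair that differs in one place only, so the cap on the amine nitrogen in the ring can now be read directly: in this assay the step is a number 8 percentage points lower from compound 3 to compound 4 (within the scatter) and so gives no sign of an effect on the maximal response. On this pair, the position takes a group of 9 heavy atoms with a six-membered aromatic ring in place of the propoxycarbonyl of 6 heavy atoms, and the two numbers cannot be told apart. Nothing measured here explains this result.

This single pair cannot separate the contribution of the aromatic ring from that of the sulfur atoms. From the compounds shown here alone, a phenoxycarbonyl cap, which keeps the ring but carries oxygen in place of sulfur, or a longer butoxycarbonyl chain could help, and whether the result holds with the thiazole-bearing aromatic ring of compound 2 also stays open.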